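Cytotoxicity at the Assay Limit: From Compound 3 to Compound 4

The compounds below may be only part of what the source reports. "The series", "measured", "known", "first", "only" and "open" are said of these compounds alone.

The three measured compounds were tested in an ADME assay on RAW264.7 cells (Mus musculus) for cytotoxicity, read by MTT assay, with a stated time of 24 h, in the presence of a further agent that is not named here; on this read-out lower numbers stand for stronger inhibition and higher numbers for weaker inhibition. Their values are:

Compound 1, `O=C1OC(Cc2nc(-c3ccccc3)no2)c2ccccc21`, gives > 40000 nM, which is a limit of the assay.
Compound 2, `O=C1OC(Cc2nc(Cc3ccccc3)no2)c2ccccc21`, gives > 40000 nM, again a limit.
Compound 3, `COCCCCOc1ccc(C(O)C2OC(=O)c3c(OC)cc(OC)cc32)cc1`, gives > 40000 nM, also a limit.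

Compound 3 therefore stands at the limit, and no number for it is known. The same holds for all three compounds, because of the limit of > 40000 nM in this assay, at which 3 of the 3 values shown sit; none of them shows measurable cytotoxicity in this assay. Going by the values given here, the single step between measured compounds that differ in one place, a step that the two limits leave unreadable from compound 1 to compound 2, is benzyl in place of phenyl on an aromatic carbon, and it cannot be read since both ends are limits.

Compound 4, `COc1cc(OC)c2c(c1)C(C(O)c1ccc(OCC3CCCCC3)cc1)OC2=O`, differs from compound 3 by cyclohexyl in place of 3-methoxypropyl on a saturated chain carbon bound to an oxygen on an aromatic ring. Among the compounds with values here, no measured step bears on this change: the only one available is unreadable, and every value shown is a limit. Within the data shown here, on this basis, compound 4 is expected to give no step in this assay beyond the usual scatter, and most likely to remain at the limit as well. The estimated step that the limit leaves unreadable from compound 3 to compound 4 is expected to be small. The estimate for compound 4 is 50000 nM, expected to lie between 20000 nM and 200000 nM.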

Compound 4, half-maximal inhibitory concentration: > 40000 nM
Compound 4: no number, only a limit; the forecaster's own chance of this, stated with the estimate: 85%; the middle value is on the limit's open side.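

Compound 4 gives [ > 40000 nM ], which is a limit of the assay and not a number. Going by these compounds alone, compound 3 also stands at a limit, so no step from compound 3 to compound 4 can be read. The compounds shown leave open at what concentration, if any, each would harm these cells, and whether exchanging 3-methoxypropyl for cyclohexyl changes that.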